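Hexadecyl chain series against acid amidase: working notes

This account rests on a few compounds, and the source may have more. Where it says the series, first, only, none or still open, it means among the compounds named here.

Four compounds sharing a long saturated chain were examined in an assay on HEK293 cells for inhibition of N-acylethanolamine-hydrolyzing acid amidase (Homo sapiens), read by scintillation counting, tested at 50 uM; a higher number here means more inhibition at the concentration tested (going by the name of the read-out), a lower number less inhibition. Compound 1 `CCCCCCCCCCCCCCCC(=O)NC1CCN(Cc2ccccc2)CC1` gives "not active" (no number reported) in this assay, and compound 2 `CCCCCCCCCCCCCCCC(=O)NN1CCN(c2cc(C)ccc2C)CC1` likewise gives "not active" (no number reported). Among the measured compounds shown here, compound 3 `CCCCCCCCCCCCCCCCOC(=O)c1ccc([N+](=O)[O-])cc1` gives 26% in this assay and is therefore the only entry with a number; the other two entries report none, so no ordering among the three can be drawn. Compound 4 `CCCCCCCCCCCCCCCCOC(=O)Nc1ccc(OC)cc1` has not been measured. It differs from compound 3 by (4-methoxyphenyl)amino in place of 4-nitrophenyl on a carbonyl carbon. For the measured compounds named here, no step between measured compounds is available to size this change; a modest rise in inhibition is expected, a number 9 percentage points higher from compound 3 to compound 4 (within the scatter), within or only just beyond the usual scatter. Compound 4 is estimated at 35% in this assay, with a range from 10% to 60%.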

Compound 4, a percentage reported as inhibition, at one concentration (the size of the read-out at that concentration, not a potency): "not active" (no number reported)
Nothing numeric was reported for compound 4; there is nothing to compare the estimate with.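

Among the compounds shown here, compound 4 carries no number, and no step from compound 3 to compound 4 can be read. No measured evidence bears on this result. The compounds shown leave open how replacing the 4-nitrophenyl of compound 3 changes inhibition.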